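Swapping Neopentyl for an Oxolane Ring on the Ether

The source may hold more compounds than are shown below. What is called first, only, known or untested is meant among the compounds shown, and "the series" means these compounds.

Compound 1 `CC1CC1COc1cccc2ccc(N)nc12` gives 1640 nM in an assay on cells with melanin-concentrating hormone receptor 1 (Homo sapiens) as the target, read by radioligand binding; a lower number here means a stronger inhibitor, a higher number a weaker inhibitor.
Compound 2 `Nc1ccc2cccc(OCC3CC3)c2n1` sits at the assay limit of > 2000 nM in this assay.
Compound 3 `CC(C)(C)CCOc1cccc2ccc(N)nc12` gives 201 nM in this assay.

Compound 3 has the lowest number of the three: the step of an 8.2-fold lower number from compound 1 to compound 3 (0.91 log units; beyond the scatter) is beyond the scatter, as is an at least 9.9-fold lower number from compound 2 to compound 3 (0.99 log units; beyond the scatter), while an at least 1.2-fold higher number from compound 1 to compound 2 (0.08 log units; that floor lies within the scatter) lies within it. Compound 4 `Nc1ccc2cccc(OCC3CCOC3)c2n1` alters the same ether side chain: oxolan-3-yl in place of neopentyl on a saturated chain carbon bound to an oxygen on an aromatic ring. The two measured steps at this position both show the neopentyl group giving a clearly lower number than a small saturated ring, so exchanging it for another saturated ring is expected to raise the number in this assay. The estimate for compound 4 thus means a 5.0-fold higher number from compound 3 to compound 4 (0.70 log units; beyond the scatter). Compound 4 is estimated at 1000 nM, within 300 nM to 3000 nM.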

Compound 4, half-maximal inhibitory concentration: 115 nM
Estimate against measurement, compound 4: 8.7-fold (0.94 log units) above, outside the stated range (below it).
By their numbers in this assay, from the lowest: compounds 4 and 3 (each within the scatter of the next); then compound 1. At a limit, above all of these: compound 2.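

At this ether position, a saturated ring is not in itself a drawback: in this assay, swapping neopentyl for oxolan-3-yl, which adds a ring oxygen and a hydrogen-bond acceptor, gives a 1.7-fold lower number from compound 3 to compound 4 (0.24 log units; within the scatter). Against the smaller all-carbon rings, compound 4 stands well apart, with a 14-fold lower number from compound 1 to compound 4 (1.15 log units; beyond the scatter) and an at least 17-fold lower number from compound 2 to compound 4 (1.24 log units; beyond the scatter). The second of these steps rests on the value of compound 2, which is a limit: the limit of > 2000 nM in this assay, at which 1 of the 4 values shown sits.

The compounds shown leave open whether the ring oxygen or the ring size matters more. A cyclopentyl ring or a pyrrolidine ring in the same place would help separate the two.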